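This account rests on a few compounds, and the source may have more. Where it says the series, first, only, none or still open, it means among the compounds named here.

Measured compounds:
compound 1, `CC(=O)Nc1ccc(S(=O)(=O)NNC(=O)c2cccnc2Nc2ccc(Cl)cc2)cc1`, > 100000 nM;
compound 2, `O=C(NNS(=O)(=O)c1ccc(F)cc1)c1cccnc1Nc1ccc(Cl)cc1Cl`, > 100000 nM.

Two compounds of the series have been run in a functional assay on K562 cells (Homo sapiens) for antiproliferative activity; a higher number here means that more compound is tolerated, a lower number that less compound is tolerated. Compound 1 gives > 100000 nM in this assay, which is a limit of the assay and not a number. Compound 2 likewise gives > 100000 nM in this assay, again a limit rather than a number. Going by the values given here, compound 1 therefore stands at the limit of > 100000 nM in this assay, at which 2 of the 2 values shown sit, and nothing among the values shown places it apart from compound 2; no step between measured compounds that differ in one place can be stated.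

The next compound, compound 3, `O=C(NNS(=O)(=O)c1ccc(Cl)cc1Cl)c1cccnc1Nc1ccc(Cl)cc1`, is obtained from compound 1 by the change (2,4-dichlorophenyl in place of 4-acetamidophenyl on a sulfonyl sulfur). The remainder of compound 1 is kept. Among the compounds with values here, with both measured compounds sitting at the limit, there is no measured step on which to size the effect of this change; the expectation is that compound 3 stays in the same region, so that the step from compound 1 to compound 3 is expected to amount to a number no higher from compound 1 to compound 3 (the limit leaves the size open), nothing beyond the scatter. Compound 3 is accordingly estimated at 100000 nM in this assay, within 20000 nM to 300000 nM, with a good chance that only a limit is reported.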

Compound 3, concentration lethal to 50% of the cells: 50100 nM
Beside the measured number, compound 3's estimate is 2.0-fold (0.30 log units) above it; the range from low to high includes it.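

In this assay compound 3 is the first compound shown to give a number rather than a limit, so the group on a sulfonyl sulfur can at least carry the series into the measurable range. As far as these compounds go, exchanging 4-acetamidophenyl for 2,4-dichlorophenyl at this place gives an at least 1.9-fold lower number from compound 1 to compound 3 (0.30 log units; that floor lies within the scatter), and the true size of this step stays unknown since one end of it is a limit. A single measured number therefore marks the start of a readable scale for this position rather than a trend, and the set is still mostly held at the limit: the limit of > 100000 nM in this assay, at which 2 of the 3 values shown sit.

The compounds shown leave open whether the step follows from the two chlorines that enter or from the acetamido group that leaves, a question that a plain phenyl, a 4-chlorophenyl or a 4-aminophenyl on the sulfonyl sulfur would help to separate. Also open, from the compounds shown here alone, is whether a non-aromatic group at this place, such as a longer alkyl chain, would give a number at all, and whether the 2,4-dichlorophenyl group gives a similar result on other versions of the core.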